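Chain extension in a thiazole-acid prostanoid series

This account rests on a few compounds, and the source may have more. Where it says the series, first, only, none or still open, it means among the compounds named here.

Compound 1 `O=C(O)c1csc([C@H]2CC[C@@H]3[C@@H](/C=C/COc4ccccc4)[C@H](O)C[C@@H]3O2)n1` carries a phenoxy group on a saturated chain carbon bound to a double-bonded chain carbon of the shared core. In a functional assay on CHO cells for agonist activity at prostaglandin E2 receptor EP4 subtype (Homo sapiens), read by HTRF and cAMP accumulation, with a stated time of 30 min (on this read-out lower numbers stand for an effect already at smaller amounts and higher numbers for an effect only at larger amounts of compound), compound 1 returns only a limit, > 10000 nM, and not a number. Compound 2 `O=C(O)c1csc([C@H]2CC[C@@H]3[C@@H](CCOc4ccccc4)[C@H](O)C[C@@H]3O2)n1` differs from compound 1 in having the double bond of that side chain reduced. In this assay compound 2 likewise sits at a limit, > 10000 nM. Both values shown so far are thus limits of the same kind: the limit of > 10000 nM in this assay, at which 2 of the 2 values shown sit. Among the compounds with values here, no measured step between two numbers exists here, so the size of any step cannot be read from the data.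

Compound 3 `O=C(O)c1csc([C@H]2CC[C@@H]3[C@@H](/C=C/CCCOc4ccccc4)[C@H](O)C[C@@H]3O2)n1` is the unmeasured member. It differs from compound 1 as follows: 2-phenoxyethyl in place of phenoxy on a saturated chain carbon bound to a double-bonded chain carbon

Since compound 1 offers only a limit, > 10000 nM, any step to compound 3 can be stated only as an expectation. The step from compound 1 to compound 3 is expected to be about a number no higher from compound 1 to compound 3 (the limit leaves the size open), that is, no movement beyond the scatter. Compound 3 is therefore expected to give about 10000 nM in this assay, within a range of 2500 nM to 40000 nM, most probably again reported as a limit.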

Compound 3, half-maximal effective concentration: > 10000 nM
Compound 3 ended at the assay's limit; the forecaster's own chance of this, stated with the estimate: 75%; the middle value sits exactly at the limit.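

No step can be read from compound 1 to compound 3 in this assay, as the values of both are limits and not numbers: the limit of > 10000 nM in this assay, at which 3 of the 3 values shown sit.

The compounds shown leave open whether any member of this series gives a number in this assay, and with it what the chain extension or the reduced double bond does to the read-out.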